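Swapping Chlorines for Fluorines on the Benzoyl Arm

This account rests on a few compounds, and the source may have more. Where it says the series, first, only, none or still open, it means among the compounds named here.

Compound 2 `CN(C(=O)NC(=O)c1ccc(Cl)c(Cl)c1)c1nc(C(F)(F)F)c(C(=O)N/N=C/c2ccc([N+](=O)[O-])cc2)s1` gives 5.12 ug/mL in a functional assay on HeLa cells (Homo sapiens) for inhibition, read by MTT assay, with a stated time of 72 h (a higher number here means a weaker inhibitor, a lower number a stronger inhibitor), the lowest of the two numbers shown, though compound 1 `CN(C(=O)NC(=O)c1ccc([N+](=O)[O-])cc1)c1nc(C(F)(F)F)c(C(=O)N/N=C/c2ccc([N+](=O)[O-])cc2)s1` with 8.42 ug/mL lies within the scatter of it. Compound 3 `CN(C(=O)NC(=O)c1ccc(F)c(F)c1)c1nc(C(F)(F)F)c(C(=O)N/N=C/c2ccc([N+](=O)[O-])cc2)s1` is not yet measured; it differs from compound 2 in one place: 3,4-difluorophenyl in place of 3,4-dichlorophenyl on a carbonyl carbon. Within the data shown here, only one measured step bears on this change, and it sits on the same carbonyl carbon: a 1.6-fold lower number from compound 1 to compound 2 (0.22 log units; within the scatter). That exchange of one substituted phenyl for another stayed within the scatter, and the present exchange is of the same kind, halogen for halogen on the phenyl that sits on the carbonyl carbon. Nothing in the measured pair points to a shift beyond the scatter in this assay, so the step of a 1.3-fold higher number from compound 2 to compound 3 (0.10 log units; within the scatter) is expected to stay within it. Compound 3 is therefore estimated at 6.5 ug/mL in this assay, with a range of 3.2 ug/mL to 13 ug/mL.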

Compound 3, half-maximal inhibitory concentration: 5.08 ug/mL
For compound 3 the middle estimate is 1.3-fold (0.11 log units) above the measured one; measured number inside the range.
By their numbers in this assay, from the lowest: compounds 3, 2 and 1 (each within the scatter of the next).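

In this assay the exchange of 3,4-dichlorophenyl for 3,4-difluorophenyl on a carbonyl carbon gives a 1.0-fold lower number from compound 2 to compound 3 (0.00 log units; within the scatter) and so adds a halogen-for-halogen change to what was known of this position, one that leaves the two halogens indistinguishable here. The exchange of 4-nitrophenyl for 3,4-difluorophenyl at the same place reads a 1.7-fold lower number from compound 1 to compound 3 (0.22 log units; within the scatter) and likewise stays within the scatter, so the three substituted phenyl groups shown on this carbonyl carbon cannot be separated in this assay. No measurement at hand accounts for this result.

From the compounds shown here alone, it remains open whether an amine, a carboxylic acid or a longer alkyl chain in place of the phenyl would move the number beyond the scatter. Going by these compounds, it is also open whether these phenyl exchanges would read the same with a different group in place of the trifluoromethyl on the shared core.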